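This account rests on a few compounds, and the source may have more. Where it says the series, first, only, none or still open, it means among the compounds named here.

Compound 1 `NCCCOc1ccc([C@H]2CC[C@]3(CC2)OOC2(O3)C3CC4CC(C3)CC2C4)cc1` is the starting point. In an ADME assay on microsomes from liver (Homo sapiens) for metabolic stability, read by LC-MS, tested at 1 uM (on this read-out lower numbers stand for slow clearance and higher numbers for fast clearance), compound 1 gives < 7 mL.min-1.g-1, which is a limit of the assay rather than a number. Compound 2 `c1cc([C@H]2CC[C@]3(CC2)OOC2(O3)C3CC4CC(C3)CC2C4)ccc1OCCC1CCNCC1` also sits at a limit in this assay, giving < 7 mL.min-1.g-1. Compound 3 `O=S(=O)(c1ccc([C@H]2CC[C@]3(CC2)OOC2(O3)C3CC4CC(C3)CC2C4)cc1)N1CCNCC1` gives a number in this assay, 16 mL.min-1.g-1. Between the two limits the step is unreadable: a step that the two limits leave unreadable from compound 1 to compound 2. The two steps that can be read both go upward: an at least 2.2-fold higher number from compound 1 to compound 3 (0.35 log units; beyond the scatter) and an at least 2.2-fold higher number from compound 2 to compound 3 (0.35 log units; beyond the scatter). The floor matters here, because of the limit of < 7 mL.min-1.g-1 in this assay, at which 2 of the 3 values shown sit.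

Compound 4 `O[C@H]1CC[C@H](NCCCOc2ccc([C@H]3CC[C@]4(CC3)OOC3(O4)C4CC5CC(C4)CC3C5)cc2)CC1` differs from compound 1 in one place: 4-hydroxycyclohexyl in place of hydrogen on an amine nitrogen. For the measured compounds named here, none of the measured steps alters the amine nitrogen in this way. Going by the values given here, the only step that touches the amine-bearing chain, from compound 1 to compound 2, cannot be sized, and the readable steps concern a different part of the molecule. Among the compounds with values here, with no step that speaks to this change, the expectation is that compound 4 stays close to where compound 1 stands, so the step of a number no lower from compound 1 to compound 4 (the limit leaves the size open) is expected to be small. Compound 4 is therefore estimated at 7 mL.min-1.g-1 in this assay, within a range from 3 mL.min-1.g-1 to 15 mL.min-1.g-1.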

Compound 4, intrinsic clearance in microsomes: < 7 mL.min-1.g-1
Compound 4: no number, only a limit; the forecaster's own chance of this, stated with the estimate: 55%; the middle value sits exactly at the limit.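

In this assay compound 4 gives < 7 mL.min-1.g-1, which is a limit of the assay and not a number. For the compounds shown here, this shows that the amine nitrogen can carry 4-hydroxycyclohexyl, a much larger substituent than hydrogen, without the read-out rising to a measurable number, and the one readable comparison, an at least 2.2-fold lower number from compound 3 to compound 4 (0.35 log units; beyond the scatter), points the same way as those from the two amine-bearing compounds 1 and 2 to the piperazin-1-yl sulfonyl compound 3. The steps that link compound 4 to compound 1 and compound 2 cannot be read, because all three sit at the same floor, so any real difference among them stays hidden: the limit of < 7 mL.min-1.g-1 in this assay, at which 3 of the 4 values shown sit.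

As far as these compounds go, how much clearance remains beneath that limit for any of these three compounds stays open, so the change may have slowed clearance, hastened it slightly or done nothing at all. The compounds shown also leave open whether a plain cyclohexyl without the hydroxyl, a small methyl or an acyl group such as acetyl on the same amine nitrogen would stay at the limit or give a number.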